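Same atoms rejoined: from compound 2 to compound 3

The compounds below may be only part of what the source reports. "The series", "measured", "known", "first", "only" and "open" are said of these compounds alone.

Measured in a functional assay on L1210 cells (Mus musculus) for inhibition; on this read-out higher numbers stand for weaker inhibition and lower numbers for stronger inhibition:
- compound 1 `CC(C)CN(NC(=O)OCc1ccccc1)C(=O)CN(Cc1ccccc1)NC(=O)CBr`: 1300 nM
- compound 2 `CC(C)CN(NC(=O)OCc1ccccc1)C(=O)CN(Cc1ccccc1)/N=C/c1cccc(B(O)O)c1`: 16200 nM

Compound 2 holds the higher of the two numbers and so shows the weaker inhibition in this assay. Compound 3 `CC(C)CN(NC(=O)OCc1ccccc1)C(=O)CN(Cc1ccccc1)/N=C/c1ccc(B(O)O)cc1` has the same atoms as compound 2, joined differently: a group of 9 heavy atoms (6 carbon, 1 boron, 2 oxygen; one six-membered aromatic ring of carbon only) in place of a group of 9 heavy atoms (6 carbon, 1 boron, 2 oxygen; one six-membered aromatic ring of carbon only), on a carbon with a double bond to nitrogen. Among the measured compounds shown here, only one measured step exists, a 12-fold higher number from compound 1 to compound 2 (1.10 log units; beyond the scatter). It is large, but it replaces one group on an amine nitrogen with a quite different one, so it bears only loosely on this change. For the measured compounds named here, no measured step shows a rearrangement of this kind. Without such evidence, no change beyond the scatter is expected, though a real shift in either direction remains possible. The expected step is a 1.2-fold lower number from compound 2 to compound 3 (0.06 log units; within the scatter). Compound 3 is estimated at 14000 nM, with an expected range of 5000 nM to 40000 nM.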

Compound 3, half-maximal inhibitory concentration: 14700 nM
Compound 3: the middle estimate sits 1.1-fold (0.02 log units) below what was measured; the measured number falls inside the stated range.
By their numbers in this assay, from the lowest: compound 1; then compounds 3 and 2 (each within the scatter of the next).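

In this assay, rejoining the same atoms in the group on a carbon with a double bond to nitrogen gives a 1.1-fold lower number from compound 2 to compound 3 (0.04 log units; within the scatter) and leaves compound 2 and compound 3 indistinguishable on this read-out. The large step seen earlier is thus not confined to one arrangement of this group: an 11-fold higher number from compound 1 to compound 3 (1.05 log units; beyond the scatter) is of similar size, and compound 1 stands apart from both. No evidence on the cause of either step is at hand. Still open, from the compounds shown here alone, is whether a carboxylic acid or an amine in place of the boronic acid on the aromatic ring would stay near the numbers of compound 2 and compound 3. Also open, going by these compounds, is whether a longer chain on the amine nitrogen would retain the number of compound 1.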